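Swapping an Amino Group for Iodine in Compound 3

The source may hold more compounds than are shown below. What is called first, only, known or untested is meant among the compounds shown, and "the series" means these compounds.

The three measured compounds share one core, seen in compound 1 `CC(/C=N/Nc1ccc([N+](=O)[O-])cc1)=N\NC(=O)c1ccccc1Nc1ccccc1`, compound 2 `CC(/C=N/Nc1ccc([N+](=O)[O-])cc1)=N\NC(=O)c1ccc(N)cc1` and compound 3 `CC(/C=N/Nc1ccc([N+](=O)[O-])cc1)=N\NC(=O)c1ccccc1N`, and differ only in the group on the ring attached to the carbonyl. In a functional assay on cells (Splenocyte, Mus musculus, strain BALB/c) for inhibition, read by scintillation counting and thymidine incorporation, with a stated time of 72 h (on this read-out higher numbers stand for weaker inhibition and lower numbers for stronger inhibition), compound 1 gives "not determined" (no result reported). In this assay compound 2 reaches only a limit of the assay, > 12000 nM, not a number. Within the data shown here, compound 3 gives 4900 nM, the only plain number among the three, so it stands alone rather than above or below any other. The step of an at least 2.4-fold lower number from compound 2 to compound 3 (0.38 log units; beyond the scatter) changes 4-aminophenyl to 2-aminophenyl; its size is known only as a lower bound because the limit of > 12000 nM in this assay, at which 1 of the 3 values shown sits, caps what compound 2 could show.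

Compound 4 `CC(/C=N/Nc1ccc([N+](=O)[O-])cc1)=N\NC(=O)c1ccccc1I` differs from compound 3 by iodo in place of amino on an aromatic carbon, ortho to a large group. Among the measured compounds shown here, no measured step exchanges one group for another at this place; the single step from compound 2 to compound 3 only moves the same amino group and says nothing about iodine. With nothing bearing on it, the expected step of a 1.0-fold higher number from compound 3 to compound 4 (0.01 log units; within the scatter) is none beyond the scatter, though with wide uncertainty. Compound 4 is therefore estimated at 5000 nM, between 1500 nM and 15000 nM.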

Compound 4, half-maximal inhibitory concentration: 2980 nM
For compound 4 the middle estimate is 1.7-fold (0.22 log units) above the measured one; the measured number falls inside the stated range.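

In this assay, iodo in place of amino on an aromatic carbon, ortho to a large group, gives a 1.6-fold lower number from compound 3 to compound 4 (0.22 log units; within the scatter), so this exchange leaves the two compounds within the usual scatter of each other. The entering iodo has 0 hydrogen-bond donors and 0 hydrogen-bond acceptors, where the leaving amino has 1 of each, so these two compounds give no sign that a donor or an acceptor on this atom is needed for the read-out. Measured against the 4-aminophenyl compound, 2-iodophenyl gives an at least 4.0-fold lower number from compound 2 to compound 4 (0.60 log units; beyond the scatter), and this size is only a lower bound because compound 2 stands at a limit of the assay, not at a number: the limit of > 12000 nM in this assay, at which 1 of the 4 values shown sits.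

Among these compounds, whether a small group such as methyl or hydroxyl, or a charged one such as a carboxylic acid, would hold the same level at this place stays open, since amino and iodo are the only two groups with numbers here. In this assay compound 1 gives "not determined" (no result reported), so nothing can be read about how a larger group at this place behaves.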